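Methylating the Sulfonamide Nitrogen of the Biphenyl Analogue

A few compounds are considered here, and "the series" means these few. Any claim that something is new, unique, unknown or untested is made for them only; others in the source may bear on it.

The measured compounds in an assay on SK-BR-3 cells for inhibition of Aromatase (Homo sapiens); on this read-out higher numbers stand for weaker inhibition and lower numbers for stronger inhibition:
compound 1, `CS(=O)(=O)Nc1ccc([N+](=O)[O-])cc1OCc1ccc(Br)cc1`, gives 5850 nM
compound 2, `CN(c1ccc([N+](=O)[O-])cc1OCc1ccc(Br)cc1)S(C)(=O)=O`, gives 330 nM
compound 3, `CS(=O)(=O)Nc1ccc([N+](=O)[O-])cc1OCc1ccc(-c2ccccc2)cc1`, gives 850 nM

Compound 2 arises from compound 1 through one change, (methyl in place of hydrogen on a sulfonamide nitrogen), and this brought an 18-fold lower number from compound 1 to compound 2 (1.25 log units; beyond the scatter). The cores of compound 1 and compound 3 differ by phenyl in place of bromo on an aromatic carbon, which brought a 6.9-fold lower number from compound 1 to compound 3 (0.84 log units; beyond the scatter).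

Compound 4, `CN(c1ccc([N+](=O)[O-])cc1OCc1ccc(-c2ccccc2)cc1)S(C)(=O)=O`, is not yet measured. It stands to compound 3 as compound 2 stands to compound 1: methyl in place of hydrogen on a sulfonamide nitrogen. The surroundings of the changed nitrogen are described in identical words for both pairs, so this is the same change made on a second core.

Its size in this assay is expected to resemble the earlier one, because an 18-fold lower number from compound 1 to compound 2 (1.25 log units; beyond the scatter) was seen on a core differing only in the group replaced in phenyl in place of bromo on an aromatic carbon; hence compound 4 is expected to show a 14-fold lower number from compound 3 to compound 4 (1.15 log units; beyond the scatter). Compound 4 is therefore estimated at 60 nM, most likely between 20 nM and 200 nM.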

Compound 4, half-maximal inhibitory concentration: 650 nM
Beside the measured number, compound 4's estimate is 11-fold (1.03 log units) below it; measured number above the stated range.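

In this assay, methyl in place of hydrogen on the sulfonamide nitrogen gave a 1.3-fold lower number from compound 3 to compound 4 (0.12 log units; within the scatter), so the large step seen on the core of compound 1 did not carry over to the core of compound 3: the same change on two cores in this assay, an 18-fold lower number (1.25 log units; beyond the scatter) from compound 1 to compound 2 and a 1.3-fold lower number (0.12 log units; within the scatter) from compound 3 to compound 4, 14-fold (1.13 log units) apart, beyond the scatter of two such steps. Read from the other direction, phenyl in place of bromo gave a 2.0-fold higher number from compound 2 to compound 4 (0.29 log units; within the scatter), so that change, too, depended on the core that carried it: the same change on two cores in this assay, a 6.9-fold lower number (0.84 log units; beyond the scatter) from compound 1 to compound 3 and a 2.0-fold higher number (0.29 log units; within the scatter) from compound 2 to compound 4, 14-fold (1.13 log units) apart, beyond the scatter of two such steps. The two changes therefore did not add up across these four compounds, but this single set of pairs does not show why, nor how the methyl step would behave on any further core.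

The compounds shown leave open whether a different group on that nitrogen, such as ethyl or a longer chain, would give steps that differ between the two cores in the same way. They also leave open whether a replacement for bromo other than phenyl, such as chloro or methoxy, would do so.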